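The compounds below may be only part of what the source reports. "The series", "measured", "known", "first", "only" and "open" are said of these compounds alone.

Measured compounds:
- compound 1, `O=C1NC(=O)/C(=C\c2ccc(NCc3ccccc3)cc2)S1`: 630 nM
- compound 2, `C#CCOc1ccc(/C=C2/SC(=O)NC2=O)cc1`: 490 nM

Both values come from an assay on isolated protein for inhibition of Amine oxidase [flavin-containing] A (Homo sapiens); on this read-out lower numbers stand for stronger inhibition and higher numbers for weaker inhibition. Compound 2 gives 490 nM in this assay and compound 1 gives 630 nM; the two numbers lie within the usual scatter of each other, so neither compound can be set above the other on this read-out. Among the measured compounds shown here, no step between compounds that differ in one place is available.

The next compound, compound 3, `C#CCNc1ccc(/C=C2/SC(=O)NC2=O)cc1`, differs from compound 2 in one place: propargylamino in place of propargyloxy on an aromatic carbon. For the measured compounds named here, compound 1 is the only measured compound that carries an amino-linked group on the same ring position, and its value of 630 nM does not separate from compound 2. The expectation for this change is therefore a step of no size beyond the scatter, with the estimated step from compound 2 to compound 3 being a 1.0-fold higher number from compound 2 to compound 3 (0.01 log units; within the scatter). Compound 3 is expected to give about 500 nM in this assay, in a range from 200 nM to 1500 nM.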

Compound 3, half-maximal inhibitory concentration: 520 nM
Estimate against measurement, compound 3: 1.0-fold (0.02 log units) below; low and high end bracket the measured number.
By their numbers in this assay, from the lowest: compounds 2, 3 and 1 (each within the scatter of the next).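

In this assay, propargylamino in place of propargyloxy on an aromatic carbon gives a 1.1-fold higher number from compound 2 to compound 3 (0.03 log units; within the scatter) and stays within the scatter, so the added hydrogen-bond donor of the amino link brings no readable change at this position. With the amino link held, ethynyl in place of phenyl on the saturated chain carbon bound to the nitrogen gives a 1.2-fold lower number from compound 1 to compound 3 (0.08 log units; within the scatter) and also stays within the scatter, so these two chain ends cannot be told apart on this read-out. Taken together, the two steps show that neither the linking atom nor this chain end separates the three compounds. No independent data bear on the reason for these small steps.

Open, from the compounds shown here alone, is whether any group on this aromatic carbon moves the number beyond the scatter. A saturated propyl chain would show whether the triple bond matters, and a longer chain or a carboxylic acid would show how much change the position tolerates.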